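Vero-cell tolerance across an isoxazole amide series

A few compounds are considered here, and "the series" means these few. Any claim that something is new, unique, unknown or untested is made for them only; others in the source may bear on it.

Compound 1 `COC(=O)c1cc(-c2cccc(NC(=O)c3ccc(OCc4ccc(Cl)cc4)cc3)c2)on1` is the reference point. In an ADME assay on Vero cells (Chlorocebus sabaeus) for cytotoxicity, read by MTT assay, with a stated time of 72 h (a higher number here means that more compound is tolerated, a lower number that less compound is tolerated), compound 1 gives > 80 ug/mL, which is a limit of the assay rather than a number (the limit of > 80 ug/mL in this assay, at which 1 of the 2 values shown sits). Compound 2 `CCCOc1ccc(C(=O)/C=C/c2ccc(C(=O)O)cc2)cc1` in this assay gives < 10 ug/mL, also a limit of the assay and not a number (the limit of < 10 ug/mL in this assay, at which 1 of the 2 values shown sits). For the measured compounds named here, the two values therefore sit at opposite ends of the measured range, with no measured step joining them.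

Compound 3 `COC(=O)c1cc(-c2cccc(NC(=O)c3ccc(/C=C/C(=O)c4ccccc4C)cc3)c2)on1` has not been measured in this assay. Relative to compound 1 the change is 2-((2-methylphenyl)carbonyl)ethenyl in place of (4-chlorobenzyl)oxy on an aromatic carbon. Compound 2 carries the same kind of carbonyl-ethenyl linkage between two aromatic rings and sits at the low limit, so the tolerated concentration of compound 3 is expected to fall well beyond the usual scatter, with an estimated step of an at least 4.0-fold lower number from compound 1 to compound 3 (0.60 log units; beyond the scatter). Compound 3 is estimated at 20 ug/mL, expected to lie between 7 ug/mL and 60 ug/mL.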

Compound 3, half-maximal cytotoxic concentration: > 25 ug/mL
Compound 3: only a limit was reported; the forecaster's own chance of this, stated with the estimate: 30%; middle value at least 1.2-fold (0.09 log units) away from the limit.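

Compound 1 gives > 80 ug/mL, a limit and not a number. For the compounds shown here, compound 3 gives > 25 ug/mL, also a limit, so no step between compound 1 and compound 3 can be read. The compounds shown leave open whether 2-((2-methylphenyl)carbonyl)ethenyl in place of (4-chlorobenzyl)oxy changes the tolerated concentration at all.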